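Swapping a nitro for a benzyloxy on a thiophene acid

The compounds below may be only part of what the source reports. "The series", "measured", "known", "first", "only" and "open" are said of these compounds alone.

Three compounds share a core in which a trisubstituted thiophene carries a trimethoxyphenyl ring and a second aryl ring. Compound 1 `CCOC(=O)c1cc(-c2cc(OC)c(OC)c(OC)c2)c(-c2ccc(OC)c([N+](=O)[O-])c2)s1` bears an ethyl ester on the thiophene and a nitro group on the second ring; in a functional assay on HT-1080 cells (Homo sapiens) for antiproliferative activity, read by MTT assay, with a stated time of 72 h (a higher number here means a weaker inhibitor, a lower number a stronger inhibitor), compound 1 gives 12700 nM. Compound 2 `CCOC(=O)c1cc(-c2cc(OC)c(OC)c(OC)c2)c(-c2ccc(OC)c(OCc3ccccc3)c2)s1` differs from it by benzyloxy in place of nitro on an aromatic carbon. In this assay compound 2 gives > 100000 nM, which is a limit of the assay rather than a number. The change therefore produced an at least 7.8-fold higher number from compound 1 to compound 2 (0.89 log units; beyond the scatter), and its true size is only bounded from below because of the limit of > 100000 nM in this assay, at which 1 of the 3 values shown sits.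

Compound 3 `COc1ccc(-c2cc(C(=O)O)sc2-c2cc(OC)c(OC)c(OC)c2)cc1[N+](=O)[O-]` carries the free acid instead of the ethyl ester; the difference between its core and that of compound 1 is not broken down here. In this assay compound 3 gives 38100 nM, the higher of the two numbers that are not limits, with compound 1 the nearer of them.

Compound 4 `COc1ccc(-c2cc(C(=O)O)sc2-c2cc(OC)c(OC)c(OC)c2)cc1OCc1ccccc1`, not yet measured, differs from compound 3 by benzyloxy in place of nitro on an aromatic carbon, which is the same change, at the same place, as that from compound 1 to compound 2. Starting from the weaker parent compound 3, the same step is expected to carry compound 4 past the upper limit of this assay, so the step is estimated as a 6.6-fold higher number from compound 3 to compound 4 (0.82 log units; beyond the scatter). Compound 4 is thus expected to give about 250000 nM, most likely reported only as a limit, within an estimated range of 60000 nM to 800000 nM.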

Compound 4, half-maximal inhibitory concentration: > 100000 nM
Compound 4: a limit, no number; the forecaster's own chance of this, stated with the estimate: 80%; the middle value is on the limit's open side.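

Benzyloxy in place of nitro gives a weaker compound on both cores, so in this assay the direction of the change carries over from the ethyl ester to the free acid, with an at least 2.6-fold higher number from compound 3 to compound 4 (0.41 log units; beyond the scatter). This does not show that the size of the change carries over as well, and the two steps cannot be ranked against each other: the same change on two cores in this assay, an at least 7.8-fold higher number (0.89 log units; beyond the scatter) from compound 1 to compound 2 and an at least 2.6-fold higher number (0.41 log units; beyond the scatter) from compound 3 to compound 4; the limit leaves it open whether they differ Compound 2 and compound 4 both end in a limit rather than a number, so each step gives only a smallest possible size, and the real loss on either core remains unknown: the limit of > 100000 nM in this assay, at which 2 of the 4 values shown sit.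

Nitro and benzyloxy are the only two groups compared at this place, so it remains open how an amine or a hydroxyl group there would behave on either core, and whether any such group would give a stronger compound than the nitro parents. Going by these compounds, it also remains open how the ethyl ester and the free acid compare once benzyloxy is in place, a question that compound 2 and compound 4 cannot answer while neither has a measured number.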